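The source may hold more compounds than are shown below. What is called first, only, known or untested is meant among the compounds shown, and "the series" means these compounds.

Series on one shared core, varied at the amine nitrogen in the ring. Compound 1 `C(#Cc1nc2c(s1)CN(C1CCCCC1)CC2)c1ccccc1` carries cyclohexyl there; in an assay on HEK293 cells for positive allosteric modulation of metabotropic glutamate receptor 5 (Homo sapiens), read by FLIPR, with a stated time of 1 h (on this read-out higher numbers stand for an effect only at larger amounts of compound and lower numbers for an effect already at smaller amounts), compound 1 reaches only the limit of > 10000 nM. Compound 2 `CCC(=O)N1CCc2nc(C#Cc3ccccc3)sc2C1` carries propanoyl; in this assay compound 2 also stops at the limit of > 10000 nM. The step that the two limits leave unreadable from compound 1 to compound 2 stays unreadable. Compound 3 `CC1CC1C(=O)N1CCc2nc(C#Cc3ccccc3)sc2C1` carries (2-methylcyclopropyl)carbonyl; in this assay compound 3 gives 9.4 nM, the only number shown. The other two values for compound 1 and compound 2 are limits (the limit of > 10000 nM in this assay, at which 2 of the 3 values shown sit). The steps of an at least 1000-fold lower number from compound 1 to compound 3 (3.02 log units; beyond the scatter) and an at least 1000-fold lower number from compound 2 to compound 3 (3.02 log units; beyond the scatter) are large. Compound 4 `COC1CC(C(=O)N2CCc3nc(C#Cc4ccccc4)sc3C2)C1` differs from compound 3 by 3-methoxycyclobutyl in place of 2-methylcyclopropyl on a carbonyl carbon. Only an at least 1000-fold lower number from compound 2 to compound 3 (3.02 log units; beyond the scatter) bears on this acyl change; the cyclic acyl is kept, so a smaller shift is expected, a 3.2-fold higher number from compound 3 to compound 4 (0.50 log units; beyond the scatter). Compound 4 is estimated at 30 nM, between 5 nM and 300 nM.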

Compound 4, half-maximal effective concentration: 640 nM
Compound 4: the middle estimate sits 21-fold (1.33 log units) below what was measured, outside the stated range (above it).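

On a carbonyl carbon, a cyclic acyl alone does not secure the low number in this assay: 3-methoxycyclobutyl in place of 2-methylcyclopropyl gives a 68-fold higher number from compound 3 to compound 4 (1.83 log units; beyond the scatter), so this position also separates one ring-bearing group from another. Part of the gain over the earlier groups remains, with an at least 15-fold lower number from compound 2 to compound 4 (1.19 log units; beyond the scatter) and an at least 15-fold lower number from compound 1 to compound 4 (1.19 log units; beyond the scatter). Both of these steps rest on a limit and are bounded on one side only: the limit of > 10000 nM in this assay, at which 2 of the 4 values shown sit.

Ring size and the methoxy group change together here, so which of them carries the step stays open. Unsubstituted cyclobutyl on the same carbonyl would separate the two.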